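The compounds below may be only part of what the source reports. "The series", "measured", "known", "first", "only" and "open" are said of these compounds alone.

Measured compounds:
- compound 1 `O=C1/C(=C/c2ccc(Br)cc2)Cc2ccccc21`: in a functional assay on MOLT-4 cells (Homo sapiens) for inhibition (on this read-out higher numbers stand for weaker inhibition and lower numbers for stronger inhibition), compound 1 gives > 500000 nM, which is a limit of the assay and not a number.
- compound 2 `Cc1ccc(/C=C2\Cc3ccccc3C2=O)cc1`: compound 2 gives > 500000 nM, again a limit of the assay.
- compound 3 `O=C1CCCCC/C1=C\c1ccc(Br)cc1`: compound 3 gives 49400 nM, the only number in the series.

Compound 1 and compound 2 share a core and differ by methyl in place of bromo on an aromatic carbon. The step that the two limits leave unreadable from compound 1 to compound 2 cannot be read, because of the limit of > 500000 nM in this assay, at which 2 of the 3 values shown sit.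

Compound 3 carries a different core; how that core differs from the core of compound 1 is not broken down here.

Compound 4 `Cc1ccc(/C=C2\CCCCCC2=O)cc1` is not yet measured. It differs from compound 3 by methyl in place of bromo on an aromatic carbon. Among the compounds with values here, this is the same kind of change as the one from compound 1 to compound 2; the two place lines differ only in that one reads "para to a large group" and the other "para to a group of 9 heavy atoms".

Since the earlier step is unreadable, the size of the step from compound 3 to compound 4 in this assay cannot be anchored to a measured step; the expectation rests on compound 3 alone, whose value 49400 nM is the starting point. The expected step is a 1.6-fold higher number from compound 3 to compound 4 (0.21 log units; within the scatter), wide in either direction. Compound 4 is estimated at 80000 nM, between 20000 nM and 400000 nM.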

Compound 4, half-maximal inhibitory concentration: > 500000 nM
Compound 4: a limit, no number; the forecaster's own chance of this, stated with the estimate: 25%; middle value at least 6.2-fold (0.79 log units) from the limit.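

Methyl in place of bromo on the core of compound 3 gives an at least 10-fold higher number from compound 3 to compound 4 (1.00 log units; beyond the scatter) in this assay, so on this core the bromo compound is the one with a readable inhibition value and the change moves the read-out towards weaker inhibition. Compound 4 gives > 500000 nM, which is a limit of the assay and not a number, so the step has a lower bound and no exact size. The same change on the core of compound 1 cannot be read, so these compounds do not show whether the step carries from one core to the other, only that the methyl compounds on both cores end at a limit: the limit of > 500000 nM in this assay, at which 3 of the 4 values shown sit.

With only bromo and methyl shown on this aromatic carbon, it remains open whether another group there, such as an amine, a carboxylic acid or a longer chain, would give a readable number in this assay on either core. On these data alone, it also remains open whether any group on the core of compound 1 would bring that core off the limit, which a true comparison of the change across the two cores would need.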